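The source may report more compounds than this note shows. Statements on the series, on what has been measured and on what is new or still open speak of the compounds shown alone.

Compound 1 `C=CC1=C(C(=O)NCCC)C(c2ccc(Cl)c(Cl)c2)OC1` was tested in a functional assay on QGY7701 cells (Homo sapiens) for cytotoxicity, read by MTT assay, with a stated time of 24 h (a lower number here means a stronger inhibitor, a higher number a weaker inhibitor), where compound 1 gives 31300 nM. That is the lowest of the two numbers in hand, though only just: compound 2 `C=CC1=C(C(=O)NCc2ccc(Cl)cc2)C(c2ccc(F)cc2)OC1` gives 36900 nM in this assay, and the gap between the two lies within the usual scatter, so the two numbers cannot be told apart. Compound 3 `C=CC1=C(C(=O)NCc2ccccc2)C(c2ccc(Cl)c(Cl)c2)OC1` has not been measured yet. It differs from compound 1 in one place: phenyl in place of ethyl on a saturated chain carbon bound to an amide-type nitrogen. For the measured compounds named here, no measured pair shows exactly this step, so its size has to be estimated. Compound 2 carries a benzyl-type group on its amide nitrogen and gives 36900 nM, close to the number for compound 1. The step of a 1.0-fold lower number from compound 1 to compound 3 (0.02 log units; within the scatter) in this assay is therefore expected to stay within the scatter, with no clear direction. Compound 3 is estimated to give 30000 nM, between 10000 nM and 90000 nM.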

Compound 3, half-maximal inhibitory concentration: > 100000 nM
Compound 3 ended at the assay's limit; the forecaster's own chance of this, stated with the estimate: 10%; middle value at least 3.3-fold (0.52 log units) away from the limit.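

Compound 3 gives > 100000 nM in this assay, and this is a limit of the assay, not a number. Replacing propyl with benzyl on the amide nitrogen, with the rest of the molecule unchanged, gives an at least 3.1-fold higher number from compound 1 to compound 3 (0.50 log units; beyond the scatter), so this position does respond to the group placed there, and here the response is a loss of activity. Only a lower bound on the size of this step can be read, as the result for compound 3 stops at the edge of the assay's range: the limit of > 100000 nM in this assay, at which 1 of the 3 values shown sits.

This single pair cannot show whether the aromatic ring itself matters or whether any group with more carbons would do the same. A cyclohexylmethyl group or a longer chain such as pentyl on the amide nitrogen would separate these two readings, and a terminal amine on the propyl chain remains an open question too.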